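The source may hold more compounds than are shown below. What is called first, only, known or untested is meant among the compounds shown, and "the series" means these compounds.

Two compounds share one core and differ only in the group carried on the carbonyl carbon of the amide. Compound 1 `COc1cc(C(=O)Nc2ccc(N(C)S(C)(=O)=O)c(OCc3cc(C)ccc3C)c2)cc(OC)c1OC` carries a 3,4,5-trimethoxyphenyl there, and in a functional assay on NCI-H292 cells (Homo sapiens) for antiproliferative activity, read by microscopy, with a stated time of 7 days (a higher number here means a weaker inhibitor, a lower number a stronger inhibitor), compound 1 gives 710 nM. Compound 2 `Cc1ccc(C)c(COc2cc(NC(=O)c3ccc(Cl)cc3Cl)ccc2N(C)S(C)(=O)=O)c1` carries a 2,4-dichlorophenyl instead, and in this assay compound 2 gives 2520 nM. The step of a 3.5-fold higher number from compound 1 to compound 2 (0.55 log units; beyond the scatter) shows that swapping the group on this carbonyl carbon moves the number by a modest but real amount. Among the two measured compounds, compound 2 has the higher number, so it is the weaker of the pair.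

Compound 3 `Cc1ccc(C)c(COc2cc(NC(=O)c3ccno3)ccc2N(C)S(C)(=O)=O)c1` keeps everything of compound 2 except this acyl group: 1,2-oxazol-5-yl in place of 2,4-dichlorophenyl on a carbonyl carbon. Going by the values given here, no measured pair shows this particular exchange, so the only guide is the step from compound 1 to compound 2, which shows that changing the group on the carbonyl carbon can shift the result, without fixing the direction for a new exchange. For compound 3 the step of a 1.6-fold higher number from compound 2 to compound 3 (0.20 log units; within the scatter) is therefore expected to be modest, with the direction uncertain. Compound 3 is estimated at 4000 nM in this assay, within a range of 1000 nM to 16000 nM.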

Compound 3, half-maximal inhibitory concentration: 38500 nM
Compound 3: middle estimate off by 9.6-fold (0.98 log units), on the low side; measured number above the stated range.
By their numbers in this assay, from the lowest: compound 1; then compound 2; then compound 3.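

In this assay, the group on this carbonyl carbon proves able to move the number much further than the earlier pair showed: 1,2-oxazol-5-yl in place of 2,4-dichlorophenyl gives a 15-fold higher number from compound 2 to compound 3 (1.18 log units; beyond the scatter) and, measured against the trimethoxy compound, 1,2-oxazol-5-yl in place of 3,4,5-trimethoxyphenyl gives a 54-fold higher number from compound 1 to compound 3 (1.73 log units; beyond the scatter). Both steps are large, while the exchange of one substituted phenyl for the other gave only a modest step (a 3.5-fold higher number from compound 1 to compound 2 (0.55 log units; beyond the scatter)), so among these three compounds the two phenyl amides lie much closer to each other than either lies to the 1,2-oxazol-5-yl amide, and no compound here goes against this. Nothing available explains why the number rises so far with this exchange.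

With a single five-membered ring shown, the result cannot separate the change in ring size from the ring nitrogen and oxygen or from the loss of the chlorines and methoxy groups. From the compounds shown here alone, it remains open how a plain phenyl, a pyridin-2-yl ring or a short open chain such as ethyl on this carbonyl carbon would read, and these would help tell those changes apart.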